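Swapping a Phenol Ring for a Hydroxypyridine in Compound 3

A few compounds are considered here, and "the series" means these few. Any claim that something is new, unique, unknown or untested is made for them only; others in the source may bear on it.

Compound 1 (`CCNc1ccc(NC(=O)c2cc(Cl)ccc2O)c(Cl)c1`) gives 30200 nM
Compound 2 (`O=C(Nc1ccc(NCc2ccc(O)cc2)cc1Cl)c1cc(Cl)ccc1O`) gives 116000 nM

Both numbers come from an ADME assay on A549 cells (Homo sapiens) for cytotoxicity, read by resazurin assay, with a stated time of 48 h (a higher number here means that more compound is tolerated, a lower number that less compound is tolerated), and compound 2, at 116000 nM, holds the higher of the two. Compound 3 (`O=C(Nc1ccc(NCc2ccc(O)nc2)cc1Cl)c1cc(Cl)ccc1O`) has not yet been measured. It carries 6-hydroxypyridin-3-yl in place of 4-hydroxyphenyl on a saturated chain carbon bound to a nitrogen on an aromatic ring.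

Among the compounds with values here, only one measured step touches this place: a 3.8-fold higher number from compound 1 to compound 2 (0.58 log units; beyond the scatter), with 4-hydroxyphenyl in place of methyl. That step was modest, and it exchanged a different pair of groups. Within the data shown here, it shows that the number in this assay can move with a change at this place, but no measured pair exchanges one of these two rings for the other. With so little to go on, no step beyond the scatter is expected in either direction, and the estimated change is a 1.1-fold higher number from compound 2 to compound 3 (0.03 log units; within the scatter) in this assay terms. Compound 3 is expected at 125000 nM (estimated range 55000 nM to 280000 nM).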

Compound 3, half-maximal cytotoxic concentration: 98500 nM
The estimate for compound 3 lay 1.3-fold (0.10 log units) above the measured number; the range from low to high includes it.
By their numbers in this assay, from the lowest: compound 1; then compounds 3 and 2 (each within the scatter of the next).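

In this assay, within the data shown here, the first direct exchange of the two rings, 6-hydroxypyridin-3-yl in place of 4-hydroxyphenyl on a saturated chain carbon bound to a nitrogen on an aromatic ring, gives a 1.2-fold lower number from compound 2 to compound 3 (0.07 log units; within the scatter), so compound 2 and compound 3 cannot be told apart here, even though the entering ring has a hetero atom and one more hydrogen-bond acceptor. Among these compounds, the earlier step showed only that a 4-hydroxyphenyl group at this place could move the number away from that of compound 1, whereas a 3.3-fold higher number from compound 1 to compound 3 (0.51 log units; beyond the scatter) shows a step beyond the scatter with the hydroxypyridine ring as well, so that step is not confined to the ring of carbon only. Nothing available explains why the two rings read alike.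

The compounds shown leave open whether the hydroxyl group on either ring matters, since none carries an unsubstituted phenyl ring or an amine or carboxylic acid in its place. They also leave open how a saturated ring such as cyclohexyl, or a longer chain between the nitrogen and the ring, would read at this place.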